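Lengthening the chain on a diaryl urea

This account rests on a few compounds, and the source may have more. Where it says the series, first, only, none or still open, it means among the compounds named here.

Measured so far: compound 1 `CCCCCCCCc1ccc(NC(=O)Nc2c(C(C)C)cccc2C(C)C)cc1`, 11 nM; compound 2 `CCCCCCCc1ccc(NC(=O)Nc2c(C(C)C)cccc2C(C)C)cc1`, 19 nM; compound 3 `CCCCCCCCCCCCc1ccc(NC(=O)Nc2c(C(C)C)cccc2C(C)C)cc1`, 15 nM, all in an assay on isolated protein for inhibition of acyl-CoA:cholesterol acyltransferase (Oryctolagus cuniculus); a lower number here means a stronger inhibitor, a higher number a weaker inhibitor.

The three compounds share one core and differ only in the length of a straight chain on the outer ring. In this assay compound 2 gives 19 nM, the largest of the three numbers, yet its steps to the others, a 1.7-fold higher number from compound 1 to compound 2 (0.24 log units; within the scatter) and a 1.3-fold lower number from compound 2 to compound 3 (0.10 log units; within the scatter), stay within the scatter, so none of the three can be called stronger or weaker than another. Compound 4 `CCCCCCCCCCc1ccc(NC(=O)Nc2c(C(C)C)cccc2C(C)C)cc1` carries the change (propyl in place of hydrogen on a saturated chain carbon, seven bonds along the chain from an aromatic carbon), giving a chain longer than that of compound 1 and shorter than that of compound 3. Among the compounds with values here, the steps that bear on it, a 1.7-fold higher number from compound 1 to compound 2 (0.24 log units; within the scatter), a 1.4-fold higher number from compound 1 to compound 3 (0.13 log units; within the scatter) and a 1.3-fold lower number from compound 2 to compound 3 (0.10 log units; within the scatter), all lie within the scatter, so no shift beyond the scatter is expected; the estimated step is a 1.5-fold lower number from compound 2 to compound 4 (0.16 log units; within the scatter). For compound 4 the expected value in this assay is 13 nM, with a range from 6 nM to 30 nM.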

Compound 4, half-maximal inhibitory concentration: 13 nM
For compound 4 middle estimate and measured number coincide at the digits printed, within the range that was stated.
By their numbers in this assay, from the lowest: compounds 1, 4, 3 and 2 (each within the scatter of the next).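

In this assay, propyl in place of hydrogen on the chain of compound 2 gives a 1.5-fold lower number from compound 2 to compound 4 (0.16 log units; within the scatter), while the comparisons with the other two chains give a 1.2-fold higher number from compound 1 to compound 4 (0.07 log units; within the scatter) and a 1.2-fold lower number from compound 3 to compound 4 (0.06 log units; within the scatter). The new chain length therefore stays within the scatter of all three earlier compounds, so this added length on the saturated chain brings no readable change in this assay, and the four compounds show no best length. Nothing measured here explains this flat result.

As far as these compounds go, it remains open whether the numbers stay this close with a shorter chain, such as butyl, or a chain longer than that of compound 3. From the compounds shown here alone, how an amine or a carboxylic acid carried on the chain would read also remains open.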